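Amide aryl swap on a weakly antiproliferative quinoline series

The compounds below may be only part of what the source reports. "The series", "measured", "known", "first", "only" and "open" are said of these compounds alone.

Measured compounds:
Compound 1 `CCN1CCN(c2cc(C)c3cc(NC(=O)c4cccc(F)c4)ccc3n2)CC1`: 24900 nM
Compound 2 `Cc1cc(NCCN2CCCC2)nc2ccc(NC(=O)c3ccc(Cl)c(Cl)c3)cc12`: 9530 nM
Compound 3 `CNc1cc(C)c2cc(NC(=O)c3ccc(Cl)c(Cl)c3)ccc2n1`: 6350 nM

In a functional assay on SK-BR-3 cells (Homo sapiens) for antiproliferative activity, read by MTT assay, with a stated time of 72 h (a lower number here means a stronger inhibitor, a higher number a weaker inhibitor), compound 1 gives the highest of the three numbers, so it is the weakest inhibitor shown; compound 2 sits nearest, compound 3 furthest, both beyond the scatter. Compound 4 `CCN1CCN(c2cc(C)c3cc(NC(=O)c4ccccc4Br)ccc3n2)CC1` differs from compound 1 only in the amide portion: 2-bromophenyl in place of 3-fluorophenyl on a carbonyl carbon. Among the compounds with values here, the single measured step, a 1.5-fold lower number from compound 2 to compound 3 (0.18 log units; within the scatter), concerns a different part of the core and tells nothing about changing the aryl group on the carbonyl. No comparison in this set therefore informs the step to compound 4, and no movement beyond the scatter is expected, a 1.0-fold higher number from compound 1 to compound 4 (0.00 log units; within the scatter). Compound 4 is thus estimated at 25000 nM, with a range from 8000 nM to 70000 nM.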

Compound 4, half-maximal inhibitory concentration: 39200 nM
Compound 4: middle estimate off by 1.6-fold (0.20 log units), on the low side; measured number inside the range.
By their numbers in this assay, from the lowest: compounds 3 and 2 (each within the scatter of the next); then compounds 1 and 4 (each within the scatter of the next).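

In this assay, within the data shown here, the first change on the carbonyl carbon, 2-bromophenyl in place of 3-fluorophenyl, gives a 1.6-fold higher number from compound 1 to compound 4 (0.20 log units; within the scatter), so this swap of one halogen-bearing phenyl for another leaves compound 1 and compound 4 indistinguishable. At this position, with the rest of the molecule held fixed, the aryl exchange alone does not lift the series out of its weak range. No measurement here explains this result. As far as these compounds go, it remains open whether an amine or a carboxylic acid on that phenyl ring, or a saturated cyclohexyl group in its place, would move the number beyond the scatter.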